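The compounds below may be only part of what the source reports. "The series", "measured", "known", "first", "only" and "open" are said of these compounds alone.

Compound 1 `CC(C)[C@H](NC(=O)COc1cccc2ccccc12)C(=O)N[C@@H](CC(=O)O)C(=O)COc1ccc2ccccc2c1`, compound 2 `CC(C)[C@H](NC(=O)COc1cccc2ccccc12)C(=O)N[C@@H](CC(=O)O)C(=O)COc1ccc(-c2ccccc2)cc1` and compound 3 `CC(C)[C@H](NC(=O)COc1cccc2ccccc12)C(=O)N[C@@H](CC(=O)O)C(=O)COc1cc(F)ccc1F` share one core and differ only in the group on an oxygen on a saturated carbon. Within the data shown here, in a functional assay on Jurkat cells (Homo sapiens) (on this read-out higher numbers stand for weaker inhibition and lower numbers for stronger inhibition), compound 2 gives 87900 nM, the only plain number among the three. Compound 1 reaches the limit of the assay, > 100000 nM. Compound 3 likewise stops at a limit, > 100000 nM. Compound 4 `CC(C)[C@H](NC(=O)COc1cccc2ccccc12)C(=O)N[C@@H](CC(=O)O)C(=O)COc1c(F)cc(F)cc1F` differs from compound 2 in one place: 2,4,6-trifluorophenyl in place of 4-phenylphenyl on an oxygen on a saturated carbon. The step that bears on it is an at least 1.1-fold higher number from compound 2 to compound 3 (0.05 log units; that floor lies within the scatter), and the limit of > 100000 nM in this assay, at which 2 of the 3 values shown sit, marks where two of the three values sit. The account therefore expects for compound 4 a shift toward weaker inhibition, likely ending at a limit again, a step of a 1.4-fold higher number from compound 2 to compound 4 (0.14 log units; within the scatter). The estimate for compound 4 is 120000 nM, within 60000 nM to 300000 nM.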

Compound 4, half-maximal inhibitory concentration: 6840 nM
Beside the measured number, compound 4's estimate is 18-fold (1.24 log units) above it; measured number outside the range, below it.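

On the oxygen on a saturated carbon, the group matters in this assay: 2,4,6-trifluorophenyl gives a 13-fold lower number from compound 2 to compound 4 (1.11 log units; beyond the scatter), the first step beyond the scatter among these compounds. The same group gives an at least 14-fold lower number from compound 3 to compound 4 (1.16 log units; beyond the scatter) and an at least 14-fold lower number from compound 1 to compound 4 (1.16 log units; beyond the scatter), so fluorine on the ring does not by itself decide the outcome, as compound 3 also carries fluorine. The last two steps are floors, each starting from a limit: the limit of > 100000 nM in this assay, at which 2 of the 4 values shown sit. The compounds shown leave open whether the gain follows the number of fluorines or their placement. They also leave open whether a 2,4,6-trichlorophenyl group would do the same.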